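A few compounds are considered here, and "the series" means these few. Any claim that something is new, unique, unknown or untested is made for them only; others in the source may bear on it.

Measured so far in a physicochemical assay for solubility, with a stated time of 18 h, at pH 7.4; a lower number here means a less soluble compound, a higher number a more soluble compound:
- compound 1, `COc1ccc(-c2ccc3c(NCCCNCc4cc(F)ccc4OC)ccnc3c2)cc1`: 32000 nM
- compound 2, `COc1ccc(F)cc1CNCCCNc1ccnc2cc(Cc3ccc(F)cc3)ccc12`: 4200 nM

For the measured compounds named here, compound 2 stands at the lower of the two numbers; its only neighbour is compound 1, and the step between them, a 7.6-fold lower number from compound 1 to compound 2 (0.88 log units; beyond the scatter), is the single step available. That step placed 4-fluorobenzyl where 4-methoxyphenyl had stood, and the number fell.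

Compound 3, `COc1ccc(F)cc1CNCCCNc1ccnc2cc(-c3ccccc3)ccc12`, differs from compound 2 as follows: phenyl in place of 4-fluorobenzyl on an aromatic carbon. This change removes the 4-fluorobenzyl whose arrival coincided with the fall from compound 1 to compound 2 and restores a directly attached six-membered aromatic ring of carbon only, though without the methoxy of compound 1. Going by the values given here, the one step that bears on it therefore points upward, and a partial return toward compound 1 is the expectation, not a full one.

For compound 3 in this assay the estimate is 12000 nM, range 4000 nM to 35000 nM, a step of a 2.9-fold higher number from compound 2 to compound 3 (0.46 log units; beyond the scatter) expected to sit beyond the scatter.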

Compound 3, solubility: 32000 nM
Compound 3: the middle estimate sits 2.7-fold (0.43 log units) below what was measured; the range from low to high includes it.
By their numbers in this assay, from the lowest: compound 2; then compounds 1 and 3 (each within the scatter of the next).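

In this assay, the directly attached phenyl reverses the whole of the drop seen with 4-fluorobenzyl on this aromatic carbon (a 7.6-fold higher number from compound 2 to compound 3 (0.88 log units; beyond the scatter)), so the lower number of compound 2 is tied to the 4-fluorobenzyl and not to the loss of 4-methoxyphenyl. The methoxy on the attached ring makes no difference that can be read here (no change at the digits printed from compound 1 to compound 3 (within the scatter)), and across these three compounds only the 4-fluorobenzyl compound stands apart. No measurement on hand explains why the numbers move this way.

Still open, from the compounds shown here alone, is whether the lower number goes with the methylene of the 4-fluorobenzyl or with its fluorine, which a plain benzyl or a 4-fluorophenyl at this carbon would separate. Going by these compounds, how an amine or a carboxylic acid on the attached ring would read also remains unknown.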